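This account rests on a few compounds, and the source may have more. Where it says the series, first, only, none or still open, it means among the compounds named here.

Compound 1 `CC(C)c1cccc(C(C)C)c1NC(=O)NCC1(c2ccc(C(C)(C)C)cc2)CCCC1` was tested in an assay on microsomes for inhibition of acyl-CoA:cholesterol acyltransferase (Oryctolagus cuniculus) (on this read-out lower numbers stand for stronger inhibition and higher numbers for weaker inhibition), where compound 1 gives 63 nM. Among the compounds with values here, of the two numbers measured so far, that is the lowest; the nearest is compound 2 `CC(C)c1cccc(C(C)C)c1NC(=O)NCC1(c2ccc(CC(C)(C)C)cc2)CCCC1`, which in this assay gives 159 nM, a step of a 2.5-fold higher number from compound 1 to compound 2 (0.40 log units; beyond the scatter) brought about by neopentyl in place of tert-butyl on an aromatic carbon. Compound 3 `CC(C)c1cccc(C(C)C)c1NC(=O)NCC1(c2cccc([N+](=O)[O-])c2)CCCC1` has not yet been measured. It differs from compound 1 in one place: 3-nitrophenyl in place of 4-(tert-butyl)phenyl on a saturated ring carbon. Within the data shown here, the only measured step touched the same aromatic ring but only swapped one small group for a slightly longer one, whereas the change to compound 3 removes that group and introduces a nitro group, so that step is a loose guide. Because even the small swap in a 2.5-fold higher number from compound 1 to compound 2 (0.40 log units; beyond the scatter) weakened inhibition, a larger loss is expected here, with wide uncertainty. For compound 3 the expected step is a 6.3-fold higher number from compound 1 to compound 3 (0.80 log units; beyond the scatter), giving an estimated 400 nM with a range from 100 nM to 2000 nM.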

Compound 3, half-maximal inhibitory concentration: 51 nM
The estimate for compound 3 lay 7.8-fold (0.89 log units) above the measured number; the measured number lies below the stated range.
By their numbers in this assay, from the lowest: compounds 3 and 1 (each within the scatter of the next); then compound 2.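

In this assay, 3-nitrophenyl in place of 4-(tert-butyl)phenyl on the saturated ring carbon gives a 1.2-fold lower number from compound 1 to compound 3 (0.09 log units; within the scatter), so a very different aromatic group fits this place with no measurable change and the tert-butyl group is not required for this level of inhibition. The other comparison, 3-nitrophenyl in place of 4-neopentylphenyl, gives a 3.1-fold lower number from compound 2 to compound 3 (0.49 log units; beyond the scatter), so the weaker number seen with 4-neopentylphenyl does not extend to every change at this place. No supporting data explain why these aromatic groups behave as they do.

On these data alone, the group and its place on the ring change together here, so it stays open whether the nitro group or its place on the ring matters more. As far as these compounds go, how an amine or a carboxylic acid in place of the nitro group, or a plain phenyl ring, would compare also remains open.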